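Bromine Added to a Cytotoxicity Series

The source may report more compounds than this note shows. Statements on the series, on what has been measured and on what is new or still open speak of the compounds shown alone.

Of the compounds shown here, three have been tested in an ADME assay on 184B5 cells (Homo sapiens) for cytotoxicity, read by sulforhodamine B assay, with a stated time of 48 h; on this read-out lower numbers stand for stronger inhibition of growth and higher numbers for weaker inhibition of growth. Compound 1 `Cc1ccc2nc(/N=C3\C(=O)N(CN(c4ccccc4)c4ccccc4)c4ccccc43)sc2c1` gives 27200 nM, compound 2 `CCN(CC)CN1C(=O)C(=O)c2c(Cl)cccc21` gives 22500 nM, and compound 3 `O=C1C(=O)N(CN2CCCCC2)c2cccc(Br)c21` gives 85200 nM. Compound 1 thus stands second highest of the three; its number and that of compound 2 lie within the scatter of each other, whereas compound 3 sits beyond the scatter, at a higher number.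

Compound 4 `Cc1ccc2nc(/N=C3\C(=O)N(CN(c4ccccc4)c4ccccc4)c4cccc(Br)c43)sc2c1` is the next to be measured. Relative to compound 1 it carries bromo in place of hydrogen on an aromatic carbon. Within the data shown here, no step between two measured compounds shows what such a change does in this assay, so only a small shift, within the scatter, is expected. Compound 4 is therefore estimated to give 24000 nM, with a range from 9000 nM to 65000 nM, an expected step of a 1.1-fold lower number from compound 1 to compound 4 (0.05 log units; within the scatter).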

Compound 4, concentration for 50% growth inhibition: 70300 nM
Compound 4: middle estimate off by 2.9-fold (0.47 log units), on the low side, outside the stated range (above it).
By their numbers in this assay, from the lowest: compounds 2 and 1 (each within the scatter of the next); then compounds 4 and 3 (each within the scatter of the next).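

Placing bromo on an aromatic carbon, ortho to a fused ring, gives in this assay a 2.6-fold higher number from compound 1 to compound 4 (0.41 log units; beyond the scatter). Among these compounds, this is the first single change that can be read directly, and it shows that this position on the core of compound 1 is sensitive to substitution: growth inhibition becomes modestly weaker. No available measurement explains this shift.

As far as these compounds go, whether bromo has the same effect on other cores remains open. So does the result of placing fluoro, methoxy or an amine at this position.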